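This account rests on a few compounds, and the source may have more. Where it says the series, first, only, none or still open, it means among the compounds named here.

Measured so far:
- compound 1 `COc1cccc(/C=C/C(=O)c2ccc(OC)c3c2OC(C)(C)C=C3)c1`: > 10000 nM (a limit)
- compound 2 `COc1ccc(C(=O)/C=C/c2cccc([N+](=O)[O-])c2)c2c1C=CC(C)(C)O2`: 4260 nM

For the measured compounds named here, in a functional assay on HT-29 cells (Homo sapiens) for antiproliferative activity, read by MTT assay, with a stated time of 24 h (on this read-out lower numbers stand for stronger inhibition and higher numbers for weaker inhibition), compound 2 gives 4260 nM, the only actual number so far. Compound 1 stands at > 10000 nM, which is a limit of the assay and not a number.

Next comes compound 3 `COc1ccc(C(=O)/C=C/c2ccccn2)c2c1C=CC(C)(C)O2`, with pyridin-2-yl in place of 3-nitrophenyl on a double-bonded chain carbon bound to a double-bonded chain carbon.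

Going by the values given here, one measured step bears on this, an at least 2.3-fold lower number from compound 1 to compound 2 (0.37 log units; beyond the scatter). It lies beyond the scatter, is modest in size and, with one end at a limit, gives only a bound. It concerns the same ring that now leaves, and the nitro group it introduced goes with that ring. Compound 3 keeps no nitro group, so the gain in that step gives no reason to expect stronger inhibition in this assay. Among the compounds with values here, a modest move towards weaker inhibition is the more likely outcome, with no measured step on a pyridine to confirm it.

The expected step is a 1.5-fold higher number from compound 2 to compound 3 (0.18 log units; within the scatter), an estimate with wide uncertainty. For compound 3 the estimated value is 6500 nM, with an expected range of 2500 nM to 15000 nM.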

Compound 3, half-maximal inhibitory concentration: 2120 nM
For compound 3 the middle estimate is 3.1-fold (0.49 log units) above the measured one; the whole stated range lies above it.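

In this assay, the swap on a double-bonded chain carbon bound to a double-bonded chain carbon is a 2.0-fold lower number from compound 2 to compound 3 (0.30 log units; within the scatter), so pyridin-2-yl and 3-nitrophenyl cannot be told apart at this position, and activity in the low micromolar range does not depend on a nitro group. The series now has a second ring at this position that separates from 3-methoxyphenyl, with an at least 4.7-fold lower number from compound 1 to compound 3 (0.67 log units; beyond the scatter), so the result shows that the ring carried here matters, and that a ring with one hetero atom serves as well as a nitro-bearing one. Compound 1 holds the limit, and the size of that step stays a bound and not a measured gap, because one end rests on a limit: the limit of > 10000 nM in this assay, at which 1 of the 3 values shown sits.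

Going by these compounds, with only one pyridine, it remains open whether the ring nitrogen itself counts or whether pyridin-2-yl simply matches 3-nitrophenyl, a question that pyridin-3-yl or pyridin-4-yl would address. Also open is how an amine or a carboxylic acid on the phenyl ring at this position would behave, as the compounds shown carry only methoxy and nitro there.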